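A few compounds are considered here, and "the series" means these few. Any claim that something is new, unique, unknown or untested is made for them only; others in the source may bear on it.

Measured so far in a functional assay on A549 cells (Homo sapiens) for antiproliferative activity, read by CCK-8 assay, with a stated time of 72 h; on this read-out lower numbers stand for stronger inhibition and higher numbers for weaker inhibition:
- compound 1 `COc1ccccc1C(=O)Nc1cccc(-c2oc3cc(-c4ccc(F)cc4)ccc3c(=O)c2O)c1` gives 11700 nM
- compound 2 `Cc1ccccc1C(=O)Nc1cccc(-c2oc3cc(-c4ccc(F)cc4)ccc3c(=O)c2O)c1` gives 17600 nM
- compound 3 `O=C(Nc1cccc(-c2oc3cc(-c4ccc(F)cc4)ccc3c(=O)c2O)c1)c1ccc(C(F)(F)F)cc1` gives 19400 nM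

Compound 3 carries the highest of the three numbers, though none of the gaps is beyond the scatter: a 1.7-fold higher number from compound 1 to compound 3 (0.22 log units; within the scatter), and a 1.1-fold higher number from compound 2 to compound 3 (0.04 log units; within the scatter). The three compounds share one core and differ only in the aryl group on the amide carbonyl. Compound 4 `O=C(Nc1cccc(-c2oc3cc(-c4ccc(F)cc4)ccc3c(=O)c2O)c1)c1cnc(Cl)nc1Cl` changes that same group: 2,4-dichloropyrimidin-5-yl in place of 4-(trifluoromethyl)phenyl on a carbonyl carbon. Going by the values given here, the steps that bear on it are the earlier carbonyl-aryl swaps, a 1.7-fold higher number from compound 1 to compound 3 (0.22 log units; within the scatter) and a 1.1-fold higher number from compound 2 to compound 3 (0.04 log units; within the scatter), plus the ring-substituent swap a 1.5-fold higher number from compound 1 to compound 2 (0.18 log units; within the scatter); all were within the scatter. Because a 1.1-fold higher number from compound 2 to compound 3 (0.04 log units; within the scatter) and a 1.7-fold higher number from compound 1 to compound 3 (0.22 log units; within the scatter) were so small, no step beyond the scatter is expected for compound 4 in this assay, a 1.1-fold lower number from compound 3 to compound 4 (0.06 log units; within the scatter). Compound 4 is thus estimated at 17000 nM, range 7000 nM to 40000 nM.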

Compound 4, half-maximal inhibitory concentration: > 100000 nM
Compound 4: no number, only a limit; the forecaster's own chance of this, stated with the estimate: 10%; middle value at least 5.8-fold (0.76 log units) from the limit.
By their numbers in this assay, from the lowest: compounds 1, 2 and 3 (each within the scatter of the next). At a limit, above all of these: compound 4.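

In this assay compound 4 gives > 100000 nM as a limit of the assay, not a number. The aryl group on the carbonyl carbon is not indifferent: the earlier swaps stayed within the scatter, whereas 2,4-dichloropyrimidin-5-yl in that place gives steps beyond it (an at least 5.1-fold higher number from compound 3 to compound 4 (0.71 log units; beyond the scatter)) and (an at least 5.6-fold higher number from compound 2 to compound 4 (0.75 log units; beyond the scatter)) and (an at least 8.5-fold higher number from compound 1 to compound 4 (0.93 log units; beyond the scatter)). Which part of the change carries these steps remains open, as the ring nitrogens and the two chlorines enter together. A 2,4-dichlorophenyl or an unsubstituted pyrimidin-5-yl on the same carbonyl carbon would separate them.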